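Methyl to ethyl on a compound at the limit

The source may report more compounds than this note shows. Statements on the series, on what has been measured and on what is new or still open speak of the compounds shown alone.

Of the compounds shown here, two have been measured in an ADME assay on CEMx174 cells (Homo sapiens) for cytotoxicity; on this read-out higher numbers stand for lower toxicity in this test and lower numbers for higher toxicity in this test. Compound 1 `CC1=C(C(=O)OCc2ccccc2)C(c2cccc(O)c2)NC(=O)N1` gives > 10000 nM, which is a limit of the assay and not a number. Compound 2 `CC1=C(C(=O)OCC2CCCCC2)C(c2cccc(O)c2)NC(=S)N1` gives > 10000 nM, again a limit and not a number. Compound 2 therefore stands at the limit of > 10000 nM in this assay, at which 2 of the 2 values shown sit, and no exact number places it.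

Compound 3 `CCC1=C(C(=O)OCC2CCCCC2)C(c2cccc(O)c2)NC(=S)N1` alters compound 2 in one place: methyl in place of hydrogen on a saturated chain carbon bound to a double-bonded ring carbon. This puts methyl in place of hydrogen on a saturated chain carbon bound to a double-bonded ring carbon, so that methyl becomes ethyl. Going by the values given here, no measured step between compounds is available to size such a change in this assay. The expectation therefore rests on the limit of compound 2, > 10000 nM.

The expected outcome is no step beyond the scatter, and the estimated step is a step that the limit leaves unreadable from compound 2 to compound 3. A result reported again only as a limit is the likeliest outcome. For compound 3 the expected value is 15000 nM, with an estimated range of 7000 nM to 40000 nM.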

Compound 3, half-maximal cytotoxic concentration: > 10000 nM
Compound 3: only a limit was reported; the forecaster's own chance of this, stated with the estimate: 85%; the middle value is on the limit's open side.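

In this assay, compound 3 is reported only as a limit of the assay and not a number, as compound 2 is, so the change of methyl to ethyl yields no readable step between compound 2 and compound 3: the limit of > 10000 nM in this assay, at which 3 of the 3 values shown sit.

The compounds shown leave open where any of their true values lies, and whether that change shifts the read-out at all.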